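The compounds below may be only part of what the source reports. "The series", "measured", "known", "first", "only" and "open" are said of these compounds alone.

The study concerns four compounds built on one shared core, two of them measured, one reported without a number, and one still to be tested. Compound 1 `Cc1cc(O)c(C(=O)/C=C/c2ccc(Br)cc2)c(-c2ccc(OCc3ccccc3)cc2)c1C(=O)/C=C/c1ccc(Br)cc1` and compound 3 `Cc1cc(O)c(C(=O)/C=C/c2ccc(Br)cc2)c(-c2ccc(Br)cc2)c1C(=O)/C=C/c1ccc(Br)cc1` were both examined in an ADME assay on HEK293 cells (Homo sapiens) for cytotoxicity, read by MTT assay, with a stated time of 24 h; a higher number here means a weaker inhibitor, a lower number a stronger inhibitor. In this assay compound 1 gives 20000 nM, and compound 3 gives 30000 nM. The two differ by a single change, (bromo in place of benzyloxy on an aromatic carbon), and the step that this change made is a 1.5-fold higher number from compound 1 to compound 3 (0.18 log units; within the scatter).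

Compound 2 `Cc1cc(O)c(C(=O)/C=C/c2ccc(Cl)cc2)c(-c2ccc(OCc3ccccc3)cc2)c1C(=O)/C=C/c1ccc(Cl)cc1` rests on a core whose difference from the core of compound 1 is not broken down here. In this assay compound 2 is reported as "not active" (no number reported), with no single number attached.

Compound 4 `Cc1cc(O)c(C(=O)/C=C/c2ccc(Cl)cc2)c(-c2ccc(Br)cc2)c1C(=O)/C=C/c1ccc(Cl)cc1` has not yet been measured in this assay. It is related to compound 2 by bromo in place of benzyloxy on an aromatic carbon, which is the same change, at the same kind of place, that converts compound 1 into compound 3. Because that change produced a 1.5-fold higher number from compound 1 to compound 3 (0.18 log units; within the scatter) between two measured compounds, a step of similar size, within the usual scatter, is expected from compound 2 to compound 4 in this assay. Since compound 2 gave no number at all, compound 4 is expected to sit at the weak end of the range that this assay can report. Compound 4 is expected to give roughly 40000 nM in this assay. The estimate for compound 4 runs from 15000 nM to 100000 nM, with a real chance that only a limit is reported.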

Compound 4, half-maximal inhibitory concentration: 25000 nM
Beside the measured number, compound 4's estimate is 1.6-fold (0.20 log units) above it, and the stated range covers the measured number.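

No new step can be read from compound 2 to compound 4, since in this assay compound 2 is reported as "not active" (no number reported). Nothing measured here offers an explanation for the value of compound 4. The compounds shown leave open whether bromo in place of benzyloxy changes the number on the core of compound 2 as little as it does on the core of compound 1.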